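This account rests on a few compounds, and the source may have more. Where it says the series, first, only, none or still open, it means among the compounds named here.

Compound 3, with the structure `Nc1nc(NCCNc2ncc(-c3ncc[nH]3)c(-c3ccc(F)cc3F)n2)ccc1[N+](=O)[O-]`, has been tested in an ADME assay on microsomes from liver (Canis lupus familiaris) for metabolic stability; on this read-out lower numbers stand for a shorter-lived compound and higher numbers for a longer-lived compound. In this assay compound 3 gives > 0.5 h, which is a limit of the assay rather than a number. Two related compounds have been through the same test. Compound 1, `N#Cc1ccc(-c2nc(NCCNc3ccc([N+](=O)[O-])c(N)n3)ncc2-c2ncc[nH]2)cc1`, gives > 0.5 h in this assay, again a limit. Compound 2, `Clc1ccc(-c2nc(NCCNc3ccccn3)ncc2-c2ncc[nH]2)c(Cl)c1`, gives > 0.5 h in this assay, also a limit. Because all three values sit at the limit of > 0.5 h in this assay, at which 3 of the 3 values shown sit, no ordering among them can be read. For the measured compounds named here, the one single-point step among the measured compounds, a step that the two limits leave unreadable from compound 1 to compound 3, is therefore not readable in size or direction.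

Compound 4, `Cc1cc(Cl)ccc1-c1nc(NCCNc2ccc([N+](=O)[O-])c(N)n2)ncc1-c1ncc[nH]1`, has not yet been measured. It differs from compound 3 in one place: 4-chloro-2-methylphenyl in place of 2,4-difluorophenyl on an aromatic carbon. Going by the values given here, no measured step bears on this change with a readable size, and all that the numbers so far show is that the shared core has stayed at the limit through two different aromatic rings at this position.

Compound 4 is therefore expected to reach the limit of this assay as well, with an estimated half-life of 1 h, between 0.5 h and 3 h. This corresponds to an expected step that the limit leaves unreadable from compound 3 to compound 4, which is no more than a guess anchored to the limit.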

Compound 4, half-life: > 0.5 h
Compound 4 was reported as a limit; the forecaster's own chance of this, stated with the estimate: 75%; the middle value does not contradict the limit.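

In this assay compound 4 gives > 0.5 h, again a limit of the assay. The steps from compound 3 and from compound 1 to compound 4 cannot be read, because all the values sit at one shared limit: the limit of > 0.5 h in this assay, at which 4 of the 4 values shown sit.

The compounds shown leave open how long each one actually lasts, and whether changing this aromatic ring alters that.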